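The source may report more compounds than this note shows. Statements on the series, on what has been measured and on what is new or still open speak of the compounds shown alone.

Measured so far in an ADME assay on HepG2 cells (Homo sapiens) for cytotoxicity, read by CellTiter-Glo and resazurin assay, with a stated time of 72 h; on this read-out higher numbers stand for an effect only at larger amounts of compound and lower numbers for an effect already at smaller amounts:
compound 1 `CC(C)N(Cc1cccc(OCCCCCC(=O)O)c1)C(=O)c1ccc(-c2cccc(-c3ccccc3)c2)cc1` gives > 26000 nM, a limit of the assay rather than a number.
compound 2 `CCOC(=O)CCCCCOc1cccc(CN(C(=O)c2ccc(-c3cccnc3)cc2)C(C)C)c1` gives > 26000 nM, likewise only a limit.

For the measured compounds named here, compound 2 thus stands at the limit of > 26000 nM in this assay, at which 2 of the 2 values shown sit, the same place as the one other value shown; no step between measured compounds is available. Compound 3 `CCOC(=O)CCCCCOc1cccc(CN(C(=O)c2ccc(-c3cccc(C(F)(F)F)c3)cc2)C(C)C)c1` differs from compound 2 by 3-(trifluoromethyl)phenyl in place of pyridin-3-yl on an aromatic carbon. With both known values at the limit, no step beyond the scatter is expected in this assay for compound 3, in either direction. For compound 3 an expected value of 30000 nM (range 10000 nM to 80000 nM) follows, meaning an expected step that the limit leaves unreadable from compound 2 to compound 3, most likely again reported as a limit.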

Compound 3, half-maximal effective concentration: > 26000 nM
Compound 3: only a limit was reported; the forecaster's own chance of this, stated with the estimate: 75%; the middle value is on the limit's open side.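

Compound 2 and compound 3 both stand at a limit of the assay in this assay, so no step can be read between them. The compounds shown leave open whether 3-(trifluoromethyl)phenyl in place of pyridin-3-yl changes the read-out at all, and at what concentration any of them would show an effect.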